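The source may report more compounds than this note shows. Statements on the series, on what has been measured and on what is new or still open speak of the compounds shown alone.

Compound 1 `CCn1c(C(=O)On2nnc3ccccc32)ccc1C(CC)(CC)c1ccc(C#CC(O)(CC)CC)c(C)c1`, compound 2 `CCn1c(C(=O)NCCCO)ccc1C(CC)(CC)c1ccc(C#CC(O)(CC)CC)c(C)c1`, compound 3 `CCn1cc(C(CC)(CC)c2ccc(C#CC(O)(CC)CC)c(C)c2)cc1C(=O)NCCN(C)C` and compound 4 `CCn1cc(C(CC)(CC)c2ccc(C#CC(O)(CC)CC)c(C)c2)cc1C(=O)NCCC(=O)O` share one core and differ at the amide end. In an assay on cells for agonist activity at vitamin D3 receptor (Homo sapiens), read by microscopy (on this read-out higher numbers stand for an effect only at larger amounts of compound and lower numbers for an effect already at smaller amounts), compound 1 gives a limit, > 50 nM. Compound 2 gives 137 nM in this assay, and compound 3 gives 19.3 nM, the lowest of the two numbers, with its gap to compound 2 beyond the scatter. The step that the limit leaves unreadable from compound 1 to compound 2 stays unreadable because of the limit of > 50 nM in this assay, at which 1 of the 3 values shown sits. Compound 4 carries carboxy in place of dimethylamino on a saturated chain carbon, two bonds along the chain from an amide-type nitrogen. Within the data shown here, no measured step bears directly on this change; the one comparable step starts from a limit. A modest weakening in this assay is expected for compound 4, a step of a 2.1-fold higher number from compound 3 to compound 4 (0.32 log units; beyond the scatter). The estimate for compound 4 is 40 nM, between 10 nM and 200 nM.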

Compound 4, half-maximal effective concentration: > 50 nM
Compound 4 ended at the assay's limit; the forecaster's own chance of this, stated with the estimate: 15%; middle value at least 1.2-fold (0.09 log units) from the limit.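

In this assay, among these compounds, the change to carboxy on this saturated chain carbon gives an at least 2.5-fold higher number from compound 3 to compound 4 (0.41 log units; beyond the scatter), the first readable step at this amide end, as the one earlier step started from a limit. Compound 4 gives > 50 nM, which is a limit and not a number. Going by these compounds, the full size of the step therefore stays unknown: the limit of > 50 nM in this assay, at which 2 of the 4 values shown sit.

The compounds shown leave open how a longer chain ending in dimethylamino or in carboxy would read here. They also leave open whether a primary amine at this chain end would stand nearer to compound 3 or to compound 4.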